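The compounds below may be only part of what the source reports. "The series", "measured", "known", "first", "only" and "open" are said of these compounds alone.

Working notes on the series: compound 2 `CCS(=O)(=O)Nc1ccc(Oc2ccc(C(F)(F)F)cc2)c(-c2cn(C)c(=O)c3[nH]ccc23)c1` sits between the two other measured members in an ADME assay on microsomes from liver (Homo sapiens) for metabolic stability, read by HPLC, using NADPH, with stated times of 5 min and 60 min, tested at 10 uM; a lower number here means slower removal, a higher number faster removal of the compound. In this assay compound 2 gives 128 mL/min/kg; compound 1 `CCS(=O)(=O)Nc1ccc(Oc2ccc(C#N)cc2)c(-c2cn(C)c(=O)c3[nH]ccc23)c1` gives 41.7 mL/min/kg and compound 3 `Cn1cc(-c2cc(NS(C)(=O)=O)ccc2Oc2ccccc2C(F)(F)F)c2cc[nH]c2c1=O` gives 533 mL/min/kg. Within the data shown here, the one single-point step available, a 3.1-fold higher number from compound 1 to compound 2 (0.49 log units; beyond the scatter), is the change of trifluoromethyl in place of cyano on an aromatic carbon. Compound 3 differs from compound 2 in more than one place, so its number is taken only as the highest of the three and not as a step.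

Compound 4 `CCS(=O)(=O)Nc1ccc(OC2CCC(N(C)C)CC2)c(-c2cn(C)c(=O)c3[nH]ccc23)c1` arises from compound 2 by 4-(dimethylamino)cyclohexyl in place of 4-(trifluoromethyl)phenyl on an oxygen on an aromatic ring. Among the measured compounds shown here, no measured pair in the set shares this change: the one known step exchanges two groups on the same aromatic ring, whereas here the whole 4-(trifluoromethyl)phenyl is replaced by 4-(dimethylamino)cyclohexyl and the ring is no longer aromatic. The expectation therefore rests on compound 2 alone, with a wide band; a modest step downward in this assay, a 1.6-fold lower number from compound 2 to compound 4 (0.20 log units; within the scatter), is the working estimate, with a step beyond the scatter in either direction still possible. For compound 4 the expected value in this assay is 80 mL/min/kg, estimated to fall between 25 mL/min/kg and 250 mL/min/kg.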

Compound 4, clearance: < 26.7 mL/min/kg
Compound 4: a limit, no number; the forecaster's own chance of this, stated with the estimate: 5%; at least 2.9-fold (0.47 log units) between middle value and limit.
By their numbers in this assay, from the lowest: compound 1; then compound 2; then compound 3. At a limit, below all of these: compound 4.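

In this assay compound 4 is recorded as a limit and not a number: the limit of < 26.7 mL/min/kg in this assay, at which 1 of the 4 values shown sits.

Until now the substituent on the oxygen on an aromatic ring had been varied only among substituted phenyl groups, and this result extends the position to a non-aromatic ring carrying an amine, with an at least 4.7-fold lower number from compound 2 to compound 4 (0.68 log units; beyond the scatter) for 4-(dimethylamino)cyclohexyl in place of 4-(trifluoromethyl)phenyl. The change from the cyano-bearing member reads an at least 1.5-fold lower number from compound 1 to compound 4 (0.19 log units; that floor lies within the scatter), and since that floor lies within the scatter, the data do not establish a real separation between these two, whereas the step away from the trifluoromethyl member is secure despite the limit.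

The change swaps the aromatic ring for a saturated one and adds the dimethylamino group in a single move, and the compounds shown do not tell which of the two carries the step, nor how far under its limit compound 4 lies. A plain cyclohexyl without the amine and a phenyl bearing a dimethylamino group would pull these two parts apart, and a primary amine on the cyclohexyl would test the amine itself.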